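Amide variation on a chlorophenyl sulfonamide series

This account rests on a few compounds, and the source may have more. Where it says the series, first, only, none or still open, it means among the compounds named here.

Measured so far in a functional assay on SH-SY5Y cells (Homo sapiens), read by MTT assay, with a stated time of 24 h; a higher number here means that more compound is needed for the effect, a lower number that less compound is needed:
Compound 1 `COc1ccc(Cl)cc1N(CC(=O)N1CCc2ccccc21)S(=O)(=O)c1ccccc1`; compound 1 gives > 20000 nM, which is a limit of this assay.
Compound 2 `COc1ccc(NC(=O)CN(c2cc(Cl)ccc2OC)S(=O)(=O)c2ccccc2)cc1`; compound 2 gives 16200 nM.
Compound 3 `CCN(CC)C(=O)CN(c1cc(Cl)ccc1OC)S(=O)(=O)c1ccccc1`; compound 3 gives > 20000 nM, again a limit of this assay.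

Compound 3 thus stands at the limit, as does compound 1, and only compound 2 returns a number: the step of an at least 1.2-fold higher number from compound 2 to compound 3 (0.09 log units; that floor lies within the scatter), while the step that the two limits leave unreadable from compound 1 to compound 3. The evidence is thin, since (the limit of > 20000 nM in this assay, at which 2 of the 3 values shown sit).

Compound 4 `COc1ccc(Cl)cc1N(CC(=O)N1CCCCC1)S(=O)(=O)c1ccccc1` differs from compound 3 by piperidin-1-yl in place of diethylamino on a carbonyl carbon. Both measured compounds carrying a tertiary amide, compound 1 and compound 3, sit at the limit; the one secondary amide, compound 2, gives a number, with an at least 1.2-fold lower number from compound 1 to compound 2 (0.09 log units; that floor lies within the scatter). For another tertiary amide no step beyond the scatter is expected, so the expected step is a step that the limit leaves unreadable from compound 3 to compound 4. Compound 4 is therefore estimated at 25000 nM, with a range from 12000 nM to 60000 nM, most likely reported again as a limit of this assay.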

Compound 4, half-maximal effective concentration: 14500 nM
Beside the measured number, compound 4's estimate is 1.7-fold (0.24 log units) above it; the measured number falls inside the stated range.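

In this assay a tertiary amide now returns a number, so a readable value at this carbonyl is no longer confined to the secondary amide of compound 2, although compound 1 and compound 3 remain at the limit. The steps of an at least 1.3-fold lower number from compound 3 to compound 4 (0.13 log units; that floor lies within the scatter) and an at least 1.3-fold lower number from compound 1 to compound 4 (0.13 log units; that floor lies within the scatter) are floors only: the limit of > 20000 nM in this assay, at which 2 of the 4 values shown sit. Against the secondary amide, the result is a 1.1-fold lower number from compound 2 to compound 4 (0.05 log units; within the scatter) and so does not separate the two amide types.

On these data alone, whether any group on this carbonyl carbon can move the number beyond the scatter remains open. So does whether a morpholine, a piperazine or a primary amide would behave like piperidin-1-yl.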